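Cyclopropyl for pyridin-4-yl on a triazole-bearing benzophenone core

The source may hold more compounds than are shown below. What is called first, only, known or untested is meant among the compounds shown, and "the series" means these compounds.

Measured compounds:
compound 1: `CNCc1nnc(C)n1-c1ccc(Cl)cc1C(=O)c1ccccc1` with 0.1 mg/kg
compound 2: `CN(C)Cc1nnc(-c2ccncc2)n1-c1ccc(Cl)cc1C(=O)c1ccccc1Cl` with 11 mg/kg

Of the compounds shown here, two have been measured in a functional assay on the whole organism (strain CF-1) for inhibition, with Mus musculus as the target; a higher number here means that more compound is needed for the effect, a lower number that less compound is needed. Compound 1 gives 0.1 mg/kg in this assay, while compound 2 gives 11 mg/kg, the highest of the two numbers; the gap between them is well beyond the usual scatter. For the measured compounds named here, the two compounds differ in several places at once, so no single step between them can be read off.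

Compound 3, `CN(C)Cc1nnc(C2CC2)n1-c1ccc(Cl)cc1C(=O)c1ccccc1Cl`, is derived from compound 2 by one change: cyclopropyl in place of pyridin-4-yl on an aromatic carbon. Going by the values given here, no measured pair shows the effect of such a change on its own, so the expectation rests on the general picture. Compound 1, which carries a much smaller group at that position, gives 0.1 mg/kg, a far lower number, though it also differs elsewhere. Compound 3 is therefore expected to move toward lower doses, with a 3.7-fold lower number from compound 2 to compound 3 (0.56 log units; beyond the scatter) as the estimated step. The estimate for compound 3 in this assay is 3 mg/kg, within a range from 0.5 mg/kg to 15 mg/kg.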

Compound 3, dose for half-maximal effect: 0.6 mg/kg
The estimate for compound 3 lay 5.0-fold (0.70 log units) above the measured number, and the stated range covers the measured number.
By their numbers in this assay, from the lowest: compound 1; then compound 3; then compound 2.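

In this assay, for the compounds shown here, cyclopropyl in place of pyridin-4-yl gives an 18-fold lower number from compound 2 to compound 3 (1.26 log units; beyond the scatter), the first single change whose effect can be read on its own. It shows that the position on the five-membered aromatic ring with 3 nitrogen is sensitive to the group it carries, and that a six-membered aromatic ring with a hetero atom is not required there for a low dose. Nothing measured here explains the size of this step.

The change removes the ring nitrogen and the hydrogen-bond acceptor and also reduces the heavy atoms, and the compounds shown do not separate these differences. Phenyl at this position would keep the six-membered aromatic ring without the ring nitrogen, while isopropyl would test an open chain against the three-membered ring.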